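A ring swap on compound 2

The compounds below may be only part of what the source reports. "The series", "measured", "known", "first", "only" and "open" are said of these compounds alone.

Three related compounds have been measured in a physicochemical assay for lipophilicity, read by HPLC, at pH 7.4; a higher number here means a more lipophilic compound, a lower number a more polar compound. Compound 1 (`C[C@@H](Oc1cc2ccn(CCC(=O)O)c2cc1Cl)c1ccccn1`) gives 2.17, compound 2 (`Cc1ccc([C@@H](C)Oc2cc3oc(=O)n(CCC(=O)O)c3cc2Cl)nc1`) gives 2.02, and compound 3 (`CCc1cc2oc(=O)n(CCC(=O)O)c2cc1Cl`) gives 1.94. Compound 2 lies within the usual scatter of both compound 1 and compound 3, so these numbers do not separate it from either, although the three structures visibly differ.

The compound still waiting for its number is compound 4 (`C[C@@H](Oc1cc2oc(=O)n(CCC(=O)O)c2cc1Cl)c1cccnn1`), which departs from compound 2 in a single place: pyridazin-3-yl in place of 5-methylpyridin-2-yl on a saturated chain carbon bound to an oxygen on an aromatic ring and a saturated chain carbon. In words, this is pyridazin-3-yl in place of 5-methylpyridin-2-yl on a saturated chain carbon bound to an oxygen on an aromatic ring and a saturated chain carbon.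

Among the compounds with values here, no pair of measured compounds shows a change of this kind, so the expectation rests on the structures alone. Starting from compound 2 at 2.02, the entering ring trades carbon for nitrogen and loses the methyl, and a lower number in this assay is expected, by more than the scatter. The estimated step is a number 0.82 log units lower from compound 2 to compound 4 (beyond the scatter). For compound 4 the expected value is 1.2, with an estimated range from 0.7 to 1.6.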

Compound 4, distribution coefficient: 0.83
The estimate for compound 4 lay 0.37 log units above the measured number, and the stated range covers the measured number.
By their numbers in this assay, from the lowest: compound 4; then compounds 3, 2 and 1 (each within the scatter of the next).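

In this assay, pyridazin-3-yl in place of 5-methylpyridin-2-yl gives a large drop (a number 1.19 log units lower from compound 2 to compound 4 (beyond the scatter)). Within the data shown here, this is the first single-place change seen, and it shows that the reading is sensitive to the ring carried on the saturated chain carbon bound to an oxygen on an aromatic ring, a sensitivity that the earlier compounds could not reveal because no two of them differed in only one place. Nothing measured here explains why the step is this large.

Going by these compounds, the swap also makes several changes at once: the methyl group leaves, a ring carbon gives way to a second ring nitrogen, and the count of hydrogen-bond acceptors rises from 1 to 2, so the share of the drop belonging to each remains unknown. A 6-methylpyridazin-3-yl group on the same core would help to separate the methyl from the ring nitrogens, while a plain phenyl ring at this place would show where a ring with no nitrogen falls in this assay.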